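Urea series: phenyl for benzyl on the amide nitrogen

A few compounds are considered here, and "the series" means these few. Any claim that something is new, unique, unknown or untested is made for them only; others in the source may bear on it.

Compound 1 `Cc1nc(NC(=O)NCc2ccccc2)c2nn(-c3ccccc3)cc2n1` stands highest of the three numbers in an assay on CHO cells for displacement of a labelled ligand from adenosine receptor A1 (Homo sapiens), read by scintillation counting, with a stated time of 120 min, tested at 1 uM; a higher number here means more inhibition at the concentration tested (going by the name of the read-out), a lower number less inhibition: compound 1 gives 26%. Compound 2 `COc1ccc(-n2cc3nc(-c4ccccc4)nc(NC(C)=O)c3n2)cc1` gives 1% in this assay, and compound 3 `Cc1nc2cn(-c3ccccc3)nc2c(=O)[nH]1` gives 1%; each lies the same distance below compound 1, beyond the scatter. Among the compounds with values here, no pair of measured compounds differs in one place, so no measured step sets a scale for a single change. Compound 4 `Cc1nc(NC(=O)Nc2ccccc2)c2nn(-c3ccccc3)cc2n1` differs from compound 1 in one place: phenyl in place of benzyl on an amide-type nitrogen. Compound 4 is expected to show little or no movement beyond the scatter in this assay, the expected step being a number 6 percentage points lower from compound 1 to compound 4 (within the scatter). Compound 4 is estimated at 20% in this assay, ranging from 5% to 45%.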

Compound 4, a percentage reported as inhibition, at one concentration (the size of the read-out at that concentration, not a potency): 1%
Beside the measured number, compound 4's estimate is 19 percentage points above it; measured number below the stated range.
By their numbers in this assay, from the lowest: compounds 2, 3 and 4 (each within the scatter of the next); then compound 1.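

Within the data shown here, this is the first single change measured: in this assay, phenyl in place of benzyl on the amide-type nitrogen gives a number 25 percentage points lower from compound 1 to compound 4 (beyond the scatter). Both groups carry one six-membered aromatic ring of carbon only, so that ring alone does not keep the inhibition seen with benzyl. Nothing available accounts for the size of this step.

From the compounds shown here alone, whether phenethyl or cyclohexylmethyl on this nitrogen would keep or raise the number remains open. A single step also leaves unsettled how far this reading holds with other groups on the shared core.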